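The compounds below may be only part of what the source reports. "The series", "measured", "known", "first", "only" and "open" are said of these compounds alone.

Compound 3 `Cc1ccc(Cl)cc1N1CCN(c2ncnc3[nH]ncc23)CC1` sits second highest of the three numbers in hand: in an assay for inhibition of ribosomal protein S6 kinase beta-1 variant D18H,T412E (Homo sapiens), read by a luciferase reporter and chemiluminescence, with a stated time of 3 h (a higher number here means a weaker inhibitor, a lower number a stronger inhibitor), compound 3 gives 13 nM, while compound 1 `Cc1ccc(Cl)cc1N1CCN(c2ncnc(N)c2[N+](=O)[O-])CC1` gives 3 nM and compound 2 `Clc1cccc(N2CCN(c3ncnc4[nH]ncc34)CC2)c1` gives 107 nM. Among the compounds with values here, the one step measured so far, an 8.2-fold lower number from compound 2 to compound 3 (0.92 log units; beyond the scatter), concerns a methyl on the aryl ring, not the core. Compound 4 `Cc1nc(N2CCN(c3cc(Cl)ccc3C)CC2)c2cn[nH]c2n1` differs from compound 3 by methyl in place of hydrogen on an aromatic carbon. Within the data shown here, no measured pair speaks directly to a methyl at this position, so the guidance is weak; the step is expected to stay within or close to the scatter, with no firm direction, as a 1.5-fold higher number from compound 3 to compound 4 (0.19 log units; within the scatter). For compound 4 the estimate in this assay is 20 nM, ranging from 6 nM to 70 nM.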

Compound 4, half-maximal inhibitory concentration: > 2000 nM
Compound 4: a limit, no number; the forecaster's own chance of this, stated with the estimate: 2%; middle value at least 100-fold (2.00 log units) away from the limit.
By their numbers in this assay, from the lowest: compound 1; then compound 3; then compound 2. At a limit, above all of these: compound 4.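

In this assay, methyl in place of hydrogen on an aromatic carbon between two ring nitrogen atoms gives an at least 150-fold higher number from compound 3 to compound 4 (2.18 log units; beyond the scatter). The same kind of change on the aryl ring went the other way, with an 8.2-fold lower number from compound 2 to compound 3 (0.92 log units; beyond the scatter), so the effect of a methyl depends strongly on where it stands in this series. The value of compound 4 is a limit and not a number, and the full size of the step stays unknown: the limit of > 2000 nM in this assay, at which 1 of the 4 values shown sits.

The compounds shown leave open whether an amine or a hydroxyl group on this carbon would give as high a number. They also leave open whether a methyl here would have the same effect on the core of compound 1.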